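Swapping Piperazine for Cyanopiperidine: What to Expect

The source may hold more compounds than are shown below. What is called first, only, known or untested is meant among the compounds shown, and "the series" means these compounds.

Two compounds have been measured in an assay on Sf9 cells for inhibition of Leucine-rich repeat serine/threonine-protein kinase 2 (Homo sapiens), read by TR-FRET, with stated times of 30 min and 2 h; on this read-out higher numbers stand for weaker inhibition and lower numbers for stronger inhibition:

compound 1 `O=C(Nc1ccnnc1)c1cc(N2CCCCC2)ccc1OCc1ccccc1` – 25.1 nM
compound 2 `O=C(Nc1ccnnc1)c1cc(N2CCNCC2)ccc1OCc1ccccc1` – 15.9 nM

Going by the values given here, compound 2 shows the lower of the two numbers in this assay, but its only neighbour is compound 1, and the step of a 1.6-fold lower number from compound 1 to compound 2 (0.20 log units; within the scatter) lies within the scatter, so the two compounds cannot be ordered on this evidence.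

Compound 3 `N#CC1CCN(c2ccc(OCc3ccccc3)c(C(=O)Nc3ccnnc3)c2)CC1` has not yet been measured. Its difference from compound 2 is 4-cyanopiperidin-1-yl in place of piperazin-1-yl on an aromatic carbon. Among the compounds with values here, the one measured step that bears on this position is the exchange of piperidin-1-yl for piperazin-1-yl, a 1.6-fold lower number from compound 1 to compound 2 (0.20 log units; within the scatter), which was within the scatter. Compound 3 returns to a piperidine ring and adds a nitrile on it; nothing measured speaks to the nitrile itself. Because a 1.6-fold lower number from compound 1 to compound 2 (0.20 log units; within the scatter) was small, the expected step of a 1.3-fold higher number from compound 2 to compound 3 (0.10 log units; within the scatter) is also judged to lie within the scatter, with the number perhaps drifting back toward that of compound 1. Compound 3 is therefore estimated at 20 nM in this assay, with a range from 8 nM to 50 nM.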

Compound 3, half-maximal inhibitory concentration: 10 nM
For compound 3 the middle estimate is 2.0-fold (0.30 log units) above the measured one; measured number inside the range.
By their numbers in this assay, from the lowest: compounds 3, 2 and 1 (each within the scatter of the next, the first and the last beyond it).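

In this assay, going by these compounds alone, the nitrile gives the first step at this position that lies beyond the scatter: with cyano in place of hydrogen on a saturated ring carbon of the piperidine, the result is a 2.5-fold lower number from compound 1 to compound 3 (0.40 log units; beyond the scatter), a modest change. The exchange of piperazin-1-yl for 4-cyanopiperidin-1-yl gives a 1.6-fold lower number from compound 2 to compound 3 (0.20 log units; within the scatter), so these two groups cannot be ordered, even though they differ in their ring hetero atoms and in the hydrogen-bond donor counted on piperazin-1-yl. The position therefore responds to a substituent on the saturated ring, but the compounds shown offer no explanation for that response.

Going by these compounds, it remains open whether this step is specific to the nitrile or would also be seen with a hydroxyl, a methyl, a primary amide or a carboxylic acid on the same ring carbon. Also unresolved is whether a nitrile-bearing chain on the piperazine nitrogen would behave in the same way, and whether the step would persist if a methoxy group replaced the benzyloxy group.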